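This account rests on a few compounds, and the source may have more. Where it says the series, first, only, none or still open, it means among the compounds named here.

In an ADME assay on cells (Peritoneal macrophage, Mus musculus) for cytotoxicity, read by CCK-8 assay, with a stated time of 24 h (a lower number here means that less compound is tolerated, a higher number that more compound is tolerated), compound 1 `COc1ccc(S(=O)(=O)N(CC(N)=O)c2ccc(N(CC(N)=O)S(=O)(=O)c3ccc(SCCCCCN=C=S)cc3)c3ccccc23)cc1` gives > 10000 nM, which is a limit of the assay and not a measured number. Compound 2 `COc1ccc(S(=O)(=O)N(CC(N)=O)c2ccc(N(CC(N)=O)S(=O)(=O)c3ccc([S+]([O-])CCCCCN=C=S)cc3)c3ccccc23)cc1` gives > 10000 nM, which is also a limit. Compound 3 `COc1ccc(S(=O)(=O)N(CC(N)=O)c2ccc(N(CC(N)=O)S(=O)(=O)c3ccc([S+]([O-])CCOCCOCCN=C=S)cc3)c3ccccc23)cc1` gives > 10000 nM, again a limit. The three compounds therefore share one position, (the limit of > 10000 nM in this assay, at which 3 of the 3 values shown sit), and none can be ranked against the others.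

Compound 4 `COc1ccc(S(=O)(=O)N(CC(N)=O)c2ccc(N(CC(N)=O)S(=O)(=O)c3ccc(S(=O)(=O)CCN=C=S)cc3)c3ccccc23)cc1` keeps the shared core of compound 1 and differs in one side chain: a group of 8 heavy atoms (3 carbon, 1 nitrogen, 2 oxygen, 2 sulfur; no ring) in place of a group of 9 heavy atoms (6 carbon, 1 nitrogen, 2 sulfur; no ring), on an aromatic carbon. The change lies on an aromatic carbon of a six-membered aromatic ring of carbon only, para to a large group.

For the measured compounds named here, two measured steps bear on this change, since both alter the same side chain. Going by the values given here, the first is a step that the two limits leave unreadable from compound 1 to compound 2, and the second is a step that the two limits leave unreadable from compound 2 to compound 3. Neither gives a size, but neither change brought a number into view, so no step beyond the scatter is expected here. The expected change is a step that the limit leaves unreadable from compound 1 to compound 4, an estimate that the assay may well hide behind its limit.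

For compound 4 the estimated value is 20000 nM, with an expected range from 8000 nM to 50000 nM.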

Compound 4, half-maximal cytotoxic concentration: > 10000 nM
Compound 4 gave a limit, no number; the forecaster's own chance of this, stated with the estimate: 85%; the middle value does not contradict the limit.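

Compound 4 joins compounds 1, 2 and 3 at one shared limit, so no step among these compounds can be read from the new result: the limit of > 10000 nM in this assay, at which 4 of the 4 values shown sit.

What the compounds shown leave open is how far any of them stands from the others in this assay, and which side chain, if any, would bring a measured number into view.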